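Replacing a Flexible Diamine with a Pyrrolidine Ring

The source may report more compounds than this note shows. Statements on the series, on what has been measured and on what is new or still open speak of the compounds shown alone.

Compound 2 `CNCCN(C)Cc1ccc(-c2ccnc3ccc(-c4cnc(OC)c(NS(=O)(=O)c5ccc(F)cc5F)c4)cc23)cc1` gives 51.8 nM in a functional assay on HCT-116 cells (Homo sapiens) for cytotoxicity, read by MTT assay, with a stated time of 72 h (on this read-out lower numbers stand for stronger inhibition and higher numbers for weaker inhibition), the lowest of the two numbers recorded here. Compound 1 `CCN(Cc1ccc(-c2ccnc3ccc(-c4cnc(OC)c(NS(=O)(=O)c5ccc(F)cc5F)c4)cc23)cc1)C1CCCCC1` gives 223 nM, and the step of a 4.3-fold lower number from compound 1 to compound 2 (0.63 log units; beyond the scatter) shows that the amine on this saturated chain carbon bound to an aromatic carbon can shift the result clearly. Compound 3 `COc1ncc(-c2ccc3nccc(-c4ccc(CN5CCCC5)cc4)c3c2)cc1NS(=O)(=O)c1ccc(F)cc1F` differs from compound 2 by pyrrolidin-1-yl in place of methyl(2-(methylamino)ethyl)amino on a saturated chain carbon bound to an aromatic carbon. Within the data shown here, no measured step covers this exact swap, so the direction is uncertain, and only a small change is expected, a 1.5-fold higher number from compound 2 to compound 3 (0.19 log units; within the scatter). The estimate for compound 3 is 80 nM, with a range from 25 nM to 300 nM.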

Compound 3, half-maximal inhibitory concentration: 18.8 nM
For compound 3 the middle estimate is 4.3-fold (0.63 log units) above the measured one; measured number outside the range, below it.
By their numbers in this assay, from the lowest: compound 3; then compound 2; then compound 1.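

In this assay, pyrrolidin-1-yl in place of methyl(2-(methylamino)ethyl)amino gives a 2.8-fold lower number from compound 2 to compound 3 (0.44 log units; beyond the scatter) and so shows that this position needs neither the open chain nor its hydrogen-bond donor for a low number. Pyrrolidin-1-yl in place of cyclohexyl(ethyl)amino gives a 12-fold lower number from compound 1 to compound 3 (1.07 log units; beyond the scatter) and is the largest step seen at this position. Nothing measured here explains either step.

Still open, on these data alone, is whether a larger ring amine, such as piperidine or morpholine, would match pyrrolidin-1-yl. A substituted pyrrolidine is equally untested among these compounds.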